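Fluoro and 4-hydroxypiperidinyl changes on a quinoxaline sulfone series

This account rests on a few compounds, and the source may have more. Where it says the series, first, only, none or still open, it means among the compounds named here.

Measured compounds:
Compound 1, `COc1ccc(S(=O)(=O)c2nc3ccccc3nc2N2CCCC2)cc1`: > 50000 nM
Compound 2, `O=S(=O)(c1ccc(F)cc1)c1nc2ccccc2nc1N1CCCC1`: 12400 nM
Compound 3, `COc1ccc(S(=O)(=O)c2nc3ccccc3nc2N2CCC(O)CC2)cc1`: 9730 nM

In a functional assay on PC-3 cells (Homo sapiens) for cytotoxicity, read by MTT assay, with a stated time of 72 h (on this read-out higher numbers stand for weaker inhibition and lower numbers for stronger inhibition), compound 1 gives only a limit, > 50000 nM. Compound 2 differs from compound 1 by fluoro in place of methoxy on an aromatic carbon. Compound 2 gives 12400 nM, and the step of an at least 4.0-fold lower number from compound 1 to compound 2 (0.60 log units; beyond the scatter) is known only as a lower bound because of the limit of > 50000 nM in this assay, at which 1 of the 3 values shown sits. Compound 3 carries a different core, differing from compound 1 by 4-hydroxypiperidin-1-yl in place of pyrrolidin-1-yl on an aromatic carbon. Going by these compounds, compound 3 gives 9730 nM; the step of an at least 5.1-fold lower number from compound 1 to compound 3 (0.71 log units; beyond the scatter) is likewise open-ended. Compound 3 and compound 2 stand within the usual scatter of one another.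

Compound 4, `O=S(=O)(c1ccc(F)cc1)c1nc2ccccc2nc1N1CCC(O)CC1`, is not yet measured. It differs from compound 3 by fluoro in place of methoxy on an aromatic carbon, the same change as from compound 1 to compound 2, made here on the core of compound 3. Resting on the step of an at least 4.0-fold lower number from compound 1 to compound 2 (0.60 log units; beyond the scatter) and on the value of compound 3, 9730 nM, compound 4 is expected to show a step of about a 2.8-fold lower number from compound 3 to compound 4 (0.44 log units; beyond the scatter). The estimated value for compound 4 in this assay is 3500 nM, expected between 1200 nM and 10000 nM.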

Compound 4, half-maximal inhibitory concentration: 2010 nM
For compound 4 the middle estimate is 1.7-fold (0.24 log units) above the measured one, within the range that was stated.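

In this assay, fluoro in place of methoxy gives a 4.8-fold lower number from compound 3 to compound 4 (0.68 log units; beyond the scatter), and this matches the direction seen on the other core: the same change on two cores in this assay, an at least 4.0-fold lower number (0.60 log units; beyond the scatter) from compound 1 to compound 2 and a 4.8-fold lower number (0.68 log units; beyond the scatter) from compound 3 to compound 4; the limit leaves it open whether they differ The change from pyrrolidin-1-yl to 4-hydroxypiperidin-1-yl gives a 6.2-fold lower number from compound 2 to compound 4 (0.79 log units; beyond the scatter), again in the direction seen before: the same change on two cores in this assay, an at least 5.1-fold lower number (0.71 log units; beyond the scatter) from compound 1 to compound 3 and a 6.2-fold lower number (0.79 log units; beyond the scatter) from compound 2 to compound 4; the limit leaves it open whether they differ Both changes therefore carry over in direction between the two cores shown, but this does not show that either keeps its size, because each earlier step starts from a limit rather than a number: the limit of > 50000 nM in this assay, at which 1 of the 4 values shown sits.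

Going by these compounds alone, the four compounds cover only two groups on the aromatic ring and two amines, so they cannot show whether a chloro or trifluoromethyl group in place of fluoro would follow the same course. Going by these compounds, it also remains open whether the two changes would carry over in the same way with a morpholine or piperazine in place of 4-hydroxypiperidin-1-yl.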